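Swapping an aryl amide for a propyl amide

The source may report more compounds than this note shows. Statements on the series, on what has been measured and on what is new or still open speak of the compounds shown alone.

Of the compounds shown here, three sharing one core have been tested in a functional assay on PC-3 cells (Homo sapiens) for cytotoxicity, read by sulforhodamine B assay, with a stated time of 72 h; a lower number here means a stronger inhibitor of growth, a higher number a weaker inhibitor of growth. Compound 1, `CC(=O)N1c2ccccc2CCC1C(=O)Nc1cc(C(F)(F)F)cc(C(F)(F)F)c1`, carries a methyl on the carbonyl carbon of the ring amide; in this assay compound 1 gives > 70000 nM, which is a limit of the assay rather than a number. Compound 2, `O=C(Nc1cc(C(F)(F)F)cc(C(F)(F)F)c1)C1CCc2ccccc2N1C(=O)c1cccc(Cl)c1`, carries a 3-chlorophenyl at that carbonyl and gives 1050 nM. Compound 3, `O=C(Nc1cc(C(F)(F)F)cc(C(F)(F)F)c1)C1CCc2ccccc2N1C(=O)c1ccccc1Cl`, carries a 2-chlorophenyl there and gives 8040 nM. Among the two numbers shown, compound 3 has the highest; the shift is a 7.7-fold higher number from compound 2 to compound 3 (0.88 log units; beyond the scatter). Replacing methyl by an aryl group gave an at least 66-fold lower number from compound 1 to compound 2 (1.82 log units; beyond the scatter) and an at least 8.7-fold lower number from compound 1 to compound 3 (0.93 log units; beyond the scatter), with the caveat (the limit of > 70000 nM in this assay, at which 1 of the 3 values shown sits).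

Compound 4, `CCCC(=O)N1c2ccccc2CCC1C(=O)Nc1cc(C(F)(F)F)cc(C(F)(F)F)c1`, differs from compound 3 by propyl in place of 2-chlorophenyl on a carbonyl carbon. The closest guide is the reverse of the step from compound 1 to compound 3, where a small alkyl at the carbonyl sat at the limit while the 2-chlorophenyl gave a number. Propyl is a small alkyl like methyl, so the number for compound 4 is expected to rise, probably by a modest to large amount, with a fair chance of only a limit.

Compound 4 is expected to give about 40000 nM, within 12000 nM to 90000 nM. That estimate means an expected 5.0-fold higher number from compound 3 to compound 4 (0.70 log units; beyond the scatter).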

Compound 4, concentration for 50% growth inhibition: 18600 nM
Estimate against measurement, compound 4: 2.2-fold (0.33 log units) above; the measured number falls inside the stated range.
By their numbers in this assay, from the lowest: compound 2; then compound 3; then compound 4. At a limit, above all of these: compound 1.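

Lengthening the methyl of compound 1 to the propyl of compound 4 gives an at least 3.7-fold lower number from compound 1 to compound 4 (0.57 log units; beyond the scatter) and so shows that a group with no ring at this carbonyl carbon can still give a measurable number. Propyl also separates the two chlorinated aryl groups: there is a 2.3-fold higher number from compound 3 to compound 4 (0.36 log units; beyond the scatter) but an 18-fold higher number from compound 2 to compound 4 (1.25 log units; beyond the scatter) so that compound 4 lies much nearer to the 2-chlorophenyl compound than to the 3-chlorophenyl compound, and what an aryl group adds over propyl depends on which of these two it is. The step from compound 1 has a limit at one end, so its full size cannot be read: the limit of > 70000 nM in this assay, at which 1 of the 4 values shown sits.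

As far as these compounds go, whether a longer chain such as butyl or hexyl would lower the number further than propyl does, or whether a chain ending in an amine or a carboxylic acid would keep any growth inhibition, remains open. Also open, from the compounds shown here alone, is how a 4-chlorophenyl or a plain phenyl at this carbonyl carbon would compare with the two chlorinated aryl groups and with propyl.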